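Fluoro on the anilide ring of compound 1

The compounds below may be only part of what the source reports. "The series", "measured", "known", "first", "only" and "open" are said of these compounds alone.

Measured compounds:
compound 1 `O=C(Nc1ccc(Oc2ccnc3[nH]ccc23)cc1)c1cc2cccnc2n(-c2ccc(F)cc2)c1=O`: 210 nM
compound 2 `COc1ccc(-n2c(=O)c(C(=O)Nc3ccc(Oc4ccnc5[nH]ccc45)cc3)cc3cccnc32)cc1`: 930 nM
compound 3 `O=C(Nc1ccc(Oc2ccnc3[nH]ccc23)cc1)c1cc2cccnc2n(-c2ccc(F)c(Cl)c2)c1=O`: 680 nM

In a functional assay on A549 cells (Homo sapiens) for antiproliferative activity, read by MTT assay, with a stated time of 72 h (on this read-out lower numbers stand for stronger inhibition and higher numbers for weaker inhibition), compound 1 gives the lowest number of the three, with compound 3 nearest and compound 2 furthest. Compound 4 `O=C(Nc1ccc(Oc2ccnc3[nH]ccc23)c(F)c1)c1cc2cccnc2n(-c2ccc(F)cc2)c1=O` is the unmeasured partner of compound 1; the change is fluoro in place of hydrogen on an aromatic carbon, on the ring that carries the amide nitrogen and the ether oxygen.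

Among the measured compounds shown here, no measured step alters that ring. The two steps from compound 1 both change the aryl group on the ring nitrogen of the core: a 4.4-fold higher number from compound 1 to compound 2 (0.65 log units; beyond the scatter) and a 3.2-fold higher number from compound 1 to compound 3 (0.51 log units; beyond the scatter). They show that this series tolerates small changes only modestly, each moving the number upward, but they bear on compound 4 only indirectly. A single fluoro is a small addition, so the step is expected to be small, if anything toward a higher number: a 1.4-fold higher number from compound 1 to compound 4 (0.15 log units; within the scatter). Compound 4 is therefore estimated at 300 nM, within 100 nM to 900 nM.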

Compound 4, half-maximal inhibitory concentration: 62 nM
Compound 4: the middle estimate sits 4.8-fold (0.68 log units) above what was measured, outside the stated range (below it).
By their numbers in this assay, from the lowest: compound 4; then compound 1; then compounds 3 and 2 (each within the scatter of the next).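

In this assay the ring that carries the amide nitrogen and the ether oxygen proves to be a place where a change can lower the number, and one fluoro, a single heavy atom, gives a 3.4-fold lower number from compound 1 to compound 4 (0.53 log units; beyond the scatter) there. Both earlier steps from compound 1 changed the aryl group on the ring nitrogen and went the other way, a 4.4-fold higher number from compound 1 to compound 2 (0.65 log units; beyond the scatter) and a 3.2-fold higher number from compound 1 to compound 3 (0.51 log units; beyond the scatter), so compound 1 is no longer the lowest point of the series. Nothing shown here accounts for the gain.

As far as these compounds go, whether a methyl group, a methoxy group or an amine on this same carbon would lower the number as well remains open. So does whether fluoro on this ring would give a similar step when paired with the aryl groups of compound 2 or compound 3.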